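This account rests on a few compounds, and the source may have more. Where it says the series, first, only, none or still open, it means among the compounds named here.

Working notes on the series. Compound 2 `O=S(=O)(CSc1nnc(Br)n1Cc1ccc(Br)c2ccccc12)Nc1cncc(C(F)(F)F)c1` gives 6380 nM in an assay on HEK293 cells for inhibition of solute carrier family 22 member 12 (Homo sapiens) (on this read-out lower numbers stand for stronger inhibition and higher numbers for weaker inhibition), and so stands lowest of the two numbers measured; the nearest is compound 1 `O=S(=O)(CSc1nnc(Br)n1Cc1ccc(Br)c2ccccc12)Nc1ccccc1`, which in this assay gives 15800 nM. Among the compounds with values here, the only step recorded, a 2.5-fold lower number from compound 1 to compound 2 (0.39 log units; beyond the scatter), concerns a change on the same sulfonamide nitrogen. Compound 3 `O=S(=O)(CSc1nnc(Br)n1Cc1ccc(Br)c2ccccc12)Nc1ccc(Cl)nc1` differs from compound 2 by 6-chloropyridin-3-yl in place of 5-(trifluoromethyl)pyridin-3-yl on a sulfonamide nitrogen. Within the data shown here, no measured step covers this exchange, and the one known step is itself modest, so the expected change in this assay is none beyond the scatter, if anything a slightly higher number. For compound 3 the estimate is 8000 nM, from 3000 nM to 22000 nM, a step of a 1.3-fold higher number from compound 2 to compound 3 (0.10 log units; within the scatter).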

Compound 3, half-maximal inhibitory concentration: 1940 nM
For compound 3 the middle estimate is 4.1-fold (0.62 log units) above the measured one, outside the stated range (below it).
By their numbers in this assay, from the lowest: compound 3; then compound 2; then compound 1.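

The group on the sulfonamide nitrogen still has room to move the read-out in this assay: 6-chloropyridin-3-yl in place of 5-(trifluoromethyl)pyridin-3-yl gives a further drop (a 3.3-fold lower number from compound 2 to compound 3 (0.52 log units; beyond the scatter)), so the two pyridines are not interchangeable here. Measured against phenyl, 6-chloropyridin-3-yl gives the largest step so far (an 8.1-fold lower number from compound 1 to compound 3 (0.91 log units; beyond the scatter)), and both pyridines shown give lower numbers than phenyl, with no compound here going against that. No measured evidence bears on what lies behind this exchange. The compounds shown leave open how much of the step rests on the chlorine itself, and how an amine or a carboxylic acid in place of that chlorine would read.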